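Quinoline ether oxime acids: cyclohexylsulfanyl for chloro

A few compounds are considered here, and "the series" means these few. Any claim that something is new, unique, unknown or untested is made for them only; others in the source may bear on it.

Measured so far:
- compound 1, `O=C(O)/C=N/OCC(c1ccc(OCc2ccc3ccccc3n2)cc1)C1CCCCC1`: 47 nM
- compound 2, `C/C(=N\OC(c1ccc(OCc2ccc3ccccc3n2)cc1Cl)C1CCCCC1)C(=O)O`: 14 nM

In a functional assay for inhibition of Polyunsaturated fatty acid 5-lipoxygenase (Homo sapiens) (on this read-out lower numbers stand for stronger inhibition and higher numbers for weaker inhibition), compound 2 gives 14 nM and stands lowest of the two numbers; compound 1, the nearest, gives 47 nM, a gap beyond the scatter. Compound 3, `C/C(=N\OC(c1ccc(OCc2ccc3ccccc3n2)cc1SC1CCCCC1)C1CCCCC1)C(=O)O`, differs from compound 2 by cyclohexylsulfanyl in place of chloro on an aromatic carbon, a cyclohexylsulfanyl in place of chloro on an aromatic carbon. Going by the values given here, no measured pair shows this change, so the size of the step rests on expectation alone. The step expected from compound 2 to compound 3 is a 1.8-fold higher number from compound 2 to compound 3 (0.25 log units; within the scatter), a small move toward weaker inhibition, close to the scatter. Compound 3 is expected to give 25 nM in this assay, with a range from 8 nM to 80 nM.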

Compound 3, half-maximal inhibitory concentration: 90 nM
Compound 3: middle estimate off by 3.6-fold (0.56 log units), on the low side; the measured number lies above the stated range.
By their numbers in this assay, from the lowest: compound 2; then compounds 1 and 3 (each within the scatter of the next).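

In this assay, this aromatic carbon does not accept cyclohexylsulfanyl in place of chloro without loss: the change gives a 6.4-fold higher number from compound 2 to compound 3 (0.81 log units; beyond the scatter), toward weaker inhibition. Going by these compounds alone, this is the first single-place comparison, and inhibition is reduced but not abolished, with compound 3 still at 90 nM. No supporting measurement bears on why the number rises.

Open, going by these compounds, is how methylsulfanyl or cyclohexyloxy would read at this carbon, and so whether the sulfur or the cyclohexyl ring accounts for the step.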